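The compounds below may be only part of what the source reports. "The series", "measured", "known", "first", "only" and "open" are said of these compounds alone.

Working notes on the series.

Compound 1 `CCC(CC)C(/C=C1\OC(=O)NC1=O)c1ccc(-c2ccc3cccc(F)c3c2)[nH]c1=O` and compound 2 `CC(C)C(c1ccc(-c2ccc3cccc(F)c3c2)[nH]c1=O)C1SC(=O)NC1=O` share the same core and the same biaryl substituent. In a functional assay on CHO cells for antagonist activity at prostaglandin E2 receptor EP3 subtype (Homo sapiens), read by cAMP accumulation, with a stated time of 30 min (a higher number here means a weaker inhibitor, a lower number a stronger inhibitor), compound 1 gives 23 nM. In this assay compound 2 gives 110 nM. Compound 1 holds the lowest of the two numbers, and the gap to compound 2 lies beyond the scatter; the two compounds differ in more than one place, so the gap is noted only as what the two values show.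

Compound 3 `O=C1NC(=O)/C(=C/C(c2ccc(-c3ccc4cccc(F)c4c3)[nH]c2=O)C2CC2)O1`, not yet measured, is the partner of compound 1 with cyclopropyl in place of pentan-3-yl on a saturated chain carbon bound to an aromatic carbon and a double-bonded chain carbon. Among the compounds with values here, no measured pair isolates this exchange. The branched five-carbon chain of compound 1 is the only measured carrier of the low number, and the smaller branched group of compound 2 sits with the higher value; on that basis a loss beyond the scatter is expected from compound 1 to compound 3, a 3.0-fold higher number from compound 1 to compound 3 (0.48 log units; beyond the scatter). Compound 3 is therefore estimated at 70 nM in this assay, with a range from 25 nM to 200 nM.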

Compound 3, half-maximal inhibitory concentration: 33 nM
Compound 3: middle estimate off by 2.1-fold (0.33 log units), on the high side; measured number inside the range.
By their numbers in this assay, from the lowest: compounds 1 and 3 (each within the scatter of the next); then compound 2.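

In this assay, cyclopropyl in place of pentan-3-yl on a saturated chain carbon bound to an aromatic carbon and a double-bonded chain carbon gives a 1.4-fold higher number from compound 1 to compound 3 (0.16 log units; within the scatter) in this series. Within the data shown here, this is the first exchange at this position that can be read on its own, and it shows that a three-membered ring of 3 heavy atoms and an open chain group of 5 heavy atoms stand here with numbers inside the scatter of each other. Nothing on hand gives a reason for this result.

From the compounds shown here alone, whether cyclohexyl, or a group carrying an amine or a carboxylic acid, would keep the number at this position remains open. Going by these compounds, compound 2 differs from compound 1 and compound 3 in more than one place, so what sets apart compound 2 at 110 nM also remains open.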